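The compounds below may be only part of what the source reports. "The series", "measured", "known", "first", "only" and "open" are said of these compounds alone.

For the measured compounds named here, compound 2 `Cn1ccc2c(Oc3ccc(NC(=O)c4cc5cccnc5n(-c5ccc(F)c(Cl)c5)c4=O)cc3)ccnc21` gives 2350 nM in a functional assay on U-87MG ATCC cells for antiproliferative activity against U-87 MG (Homo sapiens), read by MTT assay, with a stated time of 72 h (on this read-out higher numbers stand for weaker inhibition and lower numbers for stronger inhibition), the lowest of the two numbers so far; compound 1 `COc1ccc(-n2c(=O)c(C(=O)Nc3ccc(Oc4ccnc5c4ccn5C)cc3)cc3cccnc32)cc1` gives 5150 nM in this assay. Going by the values given here, the single measured step, a 2.2-fold lower number from compound 1 to compound 2 (0.34 log units; beyond the scatter), came from swapping the aryl group on the aromatic nitrogen of the shared core. Compound 3 `Cn1ccc2c(Oc3ccc(NC(=O)c4cc5cccnc5n(-c5ccc(C(F)(F)F)cc5Cl)c4=O)cc3)ccnc21` alters that same group again: 2-chloro-4-(trifluoromethyl)phenyl in place of 3-chloro-4-fluorophenyl on an aromatic nitrogen. Among the compounds with values here, that one modest step is the only guide, and it does not fix a direction for this new group. Compound 3 is therefore expected to give about 2000 nM in this assay, with a range of 600 nM to 7000 nM. This estimate means an expected step of a 1.2-fold lower number from compound 2 to compound 3 (0.07 log units; within the scatter), within the scatter.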

Compound 3, half-maximal inhibitory concentration: 12600 nM
For compound 3 the middle estimate is 6.3-fold (0.80 log units) below the measured one; the measured number lies above the stated range.
By their numbers in this assay, from the lowest: compound 2; then compound 1; then compound 3.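

In this assay, the aryl group on the aromatic nitrogen can move the number both ways: the new group gives a 5.4-fold higher number from compound 2 to compound 3 (0.73 log units; beyond the scatter), and it also gives a 2.4-fold higher number from compound 1 to compound 3 (0.39 log units; beyond the scatter). A chlorine on this aryl group therefore does not by itself secure the lower number, since both compound 2 and compound 3 carry one. No evidence here accounts for this reversal.

As far as these compounds go, compound 3 changes both the chlorine's place and the fluorine-bearing group at once, so which change carries the step remains open. From the compounds shown here alone, how a plain phenyl or a 4-aminophenyl group would read here also remains open.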